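The source may report more compounds than this note shows. Statements on the series, on what has been measured and on what is new or still open speak of the compounds shown alone.

Working notes on the series. In a functional assay on DU-145 cells (Homo sapiens) for inhibition (on this read-out lower numbers stand for stronger inhibition of growth and higher numbers for weaker inhibition of growth), compound 1 `O=S(=O)(/C=C/c1ccc(F)cc1)Cc1ccc(Nc2ncnc3ccccc23)cc1` gives 300 nM. Compound 2 `O=S(=O)(/C=C/c1ccc(Cl)cc1)Cc1ccc(Nc2ncnc3ccccc23)cc1` reaches only the limit of this assay, > 100000 nM, which is the limit of > 100000 nM in this assay, at which 1 of the 3 values shown sits. The change fluoro in place of chloro on an aromatic carbon therefore makes an at least 330-fold lower number from compound 2 to compound 1 (2.52 log units; beyond the scatter). Compound 3 `O=S(=O)(/C=C/c1ccc(F)cc1Cl)Cc1ccc(Nc2ncnc3cc(Cl)ccc23)cc1` gives 37000 nM in this assay, the highest number among the measured compounds, and compound 1 sits far lower; the difference between the cores of compound 3 and compound 2 is not broken down here. Compound 4 `O=S(=O)(/C=C/c1ccc(F)cc1F)Cc1ccc(Nc2ncnc3cc(Cl)ccc23)cc1` differs from compound 3 by fluoro in place of chloro on an aromatic carbon, the same kind of change as from compound 2 to compound 1, but here the place is ortho to a large group and meta to a fluoro group rather than para to a large group. Set beside an at least 330-fold lower number from compound 2 to compound 1 (2.52 log units; beyond the scatter), the step expected is a 25-fold lower number from compound 3 to compound 4 (1.39 log units; beyond the scatter), resting on that single earlier step. Compound 4 is estimated at 1500 nM, between 100 nM and 20000 nM.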

Compound 4, concentration for 50% growth inhibition: > 100000 nM
Compound 4 gave a limit, no number (the forecaster's own chance of this, stated with the estimate: 5%); middle value at least 66-fold (1.82 log units) away from the limit.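

In this assay, fluoro in place of chloro on an aromatic carbon gives an at least 2.7-fold higher number from compound 3 to compound 4 (0.43 log units; beyond the scatter), a step that rests on a limit for compound 4 and so has no upper size. The effect of this change therefore does not carry from one pair to the other, and the two steps run in opposite directions: the same change on two cores in this assay, an at least 330-fold lower number (2.52 log units; beyond the scatter) from compound 2 to compound 1 and an at least 2.7-fold higher number (0.43 log units; beyond the scatter) from compound 3 to compound 4, at least 900-fold (2.95 log units) apart, beyond the scatter of two such steps

Which difference sets the direction is not shown; the two pairs differ in both the core and the place of the change, and each step rests on a limit: the limit of > 100000 nM in this assay, at which 2 of the 4 values shown sit.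

On these data alone, whether the change behaves alike at both places on a single core remains open. Also open, as far as these compounds go, is how a methoxy group or an amine at the same place compares with fluoro and chloro.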